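Replacing a trifluoromethylphenyl urea terminus with a difluorophenyl one

The source may report more compounds than this note shows. Statements on the series, on what has been measured and on what is new or still open speak of the compounds shown alone.

Compound 3 `CCN(CC)CCn1cnnc1-c1cc(Oc2ccc(NC(=O)Nc3ccccc3C(F)(F)F)cc2F)ccn1` carries a 2-(trifluoromethyl)phenyl group on the urea nitrogen and shows the highest number among the two measured values in a functional assay on MDA-MB-231 cells (Homo sapiens) for antiproliferative activity, read by MTT assay, with a stated time of 72 h; on this read-out lower numbers stand for stronger inhibition and higher numbers for weaker inhibition. Its nearest neighbour, compound 2 `CCN(CC)CCn1cnnc1-c1cc(Oc2ccc(NC(=O)Nc3cccc(C(F)(F)F)c3)cc2F)ccn1`, gives 720 nM, while compound 3 gives 11600 nM; the step of a 16-fold higher number from compound 2 to compound 3 (1.21 log units; beyond the scatter) is large and lies beyond the scatter. Compound 1 `CN(C)CCn1cnnc1-c1cc(Oc2ccc(NC(=O)Nc3ccc(F)c(F)c3)cc2F)ccn1` carries the 3,4-difluorophenyl group together with a dimethylamino chain, and in this assay compound 1 reaches only the limit > 50000 nM, so no number is known for it (the limit of > 50000 nM in this assay, at which 1 of the 3 values shown sits). Compound 4 `CCN(CC)CCn1cnnc1-c1cc(Oc2ccc(NC(=O)Nc3ccc(F)c(F)c3)cc2F)ccn1` now arises from compound 3 by the change (3,4-difluorophenyl in place of 2-(trifluoromethyl)phenyl on an amide-type nitrogen). For the measured compounds named here, the only measured step that bears on it, from compound 2 to compound 3, concerns moving the trifluoromethyl group, not the entry of a 3,4-difluorophenyl group, so it gives no direct guide. Compound 4 is therefore expected near 20000 nM, within 3000 nM to 100000 nM, which amounts to the expected step of a 1.7-fold higher number from compound 3 to compound 4 (0.24 log units; within the scatter).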

Compound 4, half-maximal inhibitory concentration: 41300 nM
Compound 4: the middle estimate sits 2.1-fold (0.31 log units) below what was measured; measured number inside the range.
By their numbers in this assay, from the lowest: compound 2; then compound 3; then compound 4. At a limit, above all of these: compound 1.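

With the diethylamino chain held fixed, 3,4-difluorophenyl on the amide-type nitrogen gives the highest number of the three groups compared in this assay, with a 3.6-fold higher number from compound 3 to compound 4 (0.55 log units; beyond the scatter) and a 57-fold higher number from compound 2 to compound 4 (1.76 log units; beyond the scatter). Both replacements of 3-(trifluoromethyl)phenyl therefore weaken inhibition, and the new one does so even though it does not merely move the trifluoromethyl group but removes it. The change from dimethylamino to diethylamino gives an at least 1.2-fold lower number from compound 1 to compound 4 (0.08 log units; that floor lies within the scatter), so its size remains unresolved. Compound 1 stands at a limit, not a number: the limit of > 50000 nM in this assay, at which 1 of the 4 values shown sits.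

The compounds shown leave open how a chlorophenyl or methoxyphenyl group on the same nitrogen would compare. They also leave open whether a morpholine in place of diethylamino would alter the order of these groups.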